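This account rests on a few compounds, and the source may have more. Where it says the series, first, only, none or still open, it means among the compounds named here.

Compound 1 `Cn1cc(C2=C(c3n[nH]c4ncccc34)C(=O)N(c3cccc4ccccc34)C2=O)c2ccccc21` gives > 100000 nM in a functional assay on SMMC-7721 cells (Homo sapiens) for antiproliferative activity, read by MTT assay, with a stated time of 48 h (a higher number here means a weaker inhibitor, a lower number a stronger inhibitor), which is a limit of the assay and not a number.
Compound 2 `Cn1cc(C2=C(c3nn(CCCn4cccc4)c4ncccc34)C(=O)N(c3ccccc3)C2=O)c2ccccc21` gives > 100000 nM in this assay, again a limit.

Compound 2 therefore stands only at a limit, with no number known for it, and both values shown sit at the limit of > 100000 nM in this assay, at which 2 of the 2 values shown sit. Compound 3 `Cn1cc(C2=C(c3nn(CCCn4ccnc4)c4ncccc34)C(=O)N(c3ccccc3)C2=O)c2ccccc21` differs from compound 2 by 1H-imidazol-1-yl in place of 1H-pyrrol-1-yl on a saturated chain carbon, three bonds along the chain from an aromatic nitrogen. Within the data shown here, no step between measured compounds is known, so in this assay a step of no size beyond the scatter is expected. Compound 3 is thus expected to give 150000 nM, within 60000 nM to 400000 nM. The expected step comes to a step that the limit leaves unreadable from compound 2 to compound 3.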

Compound 3, half-maximal inhibitory concentration: 34800 nM
Compound 3: middle estimate off by 4.3-fold (0.63 log units), on the high side, and the stated range ends above it.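

Among these compounds, this is the first change at this position that moves the read-out off the limit: in this assay, 1H-imidazol-1-yl in place of 1H-pyrrol-1-yl on a saturated chain carbon gives an at least 2.8-fold lower number from compound 2 to compound 3 (0.45 log units; beyond the scatter). Both groups are five-membered aromatic rings, so the pair differs only in the hetero atoms of that ring. The true size of the step stays unknown because compound 2 has a limit and not a number: the limit of > 100000 nM in this assay, at which 2 of the 3 values shown sit.

From the compounds shown here alone, whether an amine such as morpholine would serve at this position remains open. Also open, going by these compounds, is whether a longer chain carrying 1H-imidazol-1-yl would change the read-out.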